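Swapping the Whole Sulfonyl Aryl Group in a Weak Series

The compounds below may be only part of what the source reports. "The series", "measured", "known", "first", "only" and "open" are said of these compounds alone.

Of the compounds shown here, three built on one shared core have been measured in a functional assay on PC-3 cells (Homo sapiens) for inhibition; a higher number here means a weaker inhibitor, a lower number a stronger inhibitor. Compound 1 `COc1cc2nc(N3CCN(S(=O)(=O)c4ccc(Br)cc4)CC3)nc(N)c2cc1OC` gives 20000 nM. Compound 2 `COc1cc2nc(N3CCN(S(=O)(=O)c4ccc([N+](=O)[O-])cc4)CC3)nc(N)c2cc1OC` gives 36000 nM, and compound 3 `COc1cc2nc(N3CCN(S(=O)(=O)c4ccc(S(C)(=O)=O)cc4)CC3)nc(N)c2cc1OC` gives 17000 nM. Among these, compound 3 is separated from compound 2 by a modest step beyond the scatter, a 2.1-fold lower number from compound 2 to compound 3 (0.33 log units; beyond the scatter), while compound 1 and compound 3 sit within the scatter of each other, a 1.2-fold lower number from compound 1 to compound 3 (0.07 log units; within the scatter). The remaining step, a 1.8-fold higher number from compound 1 to compound 2 (0.26 log units; within the scatter), is also within the scatter. Exchanging one group on the aromatic ring for another therefore moves the numbers very little here.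

Compound 4 `COc1cc2nc(N3CCN(S(=O)(=O)c4cc(Cl)ccc4Cl)CC3)nc(N)c2cc1OC` is built from compound 3 by a different kind of change: 2,5-dichlorophenyl in place of 4-(methylsulfonyl)phenyl on a sulfonyl sulfur. Within the data shown here, none of the measured steps exchanges the whole ring in this way, and none introduces chlorine, so there is no direct precedent. Because compound 3 gives 17000 nM and every measured step is small, a step of similar size is expected for compound 4: a 1.2-fold higher number from compound 3 to compound 4 (0.07 log units; within the scatter). For compound 4 a value of 20000 nM is expected in this assay, with a range from 7000 nM to 60000 nM.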

Compound 4, half-maximal inhibitory concentration: 60000 nM
Compound 4: the middle estimate sits 3.0-fold (0.48 log units) below what was measured; measured number inside the range.
By their numbers in this assay, from the lowest: compounds 3, 1, 2 and 4 (each within the scatter of the next, the first and the last beyond it).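

In this assay, putting 2,5-dichlorophenyl on the sulfonyl sulfur gives a modest weakening against two of the earlier rings, with a 3.5-fold higher number from compound 3 to compound 4 (0.55 log units; beyond the scatter) and a 3.0-fold higher number from compound 1 to compound 4 (0.48 log units; beyond the scatter). The 4-nitrophenyl ring does not separate from it, with a 1.7-fold higher number from compound 2 to compound 4 (0.22 log units; within the scatter), so the new ring stands apart from only part of the series and the full spread remains narrow. No supporting measurement bears on what lies behind these steps.

As far as these compounds go, compound 4 alters the ring's groups and their placing in a single change, so the share of each chlorine stays open, as would a ring carrying just one chlorine. Also open, from the compounds shown here alone, is how an amine or a carboxylic acid on the ring, or a simple alkyl chain in place of the whole ring, would read in this assay.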